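A few compounds are considered here, and "the series" means these few. Any claim that something is new, unique, unknown or untested is made for them only; others in the source may bear on it.

Measured so far:
- compound 1 `COc1ccc(-c2cc(=O)c3c(OC)cc(OC)cc3n2S(=O)(=O)c2ccc(C)c([N+](=O)[O-])c2)cc1`: > 51700 nM
- compound 2 `COc1cc(OC)c2c(=O)cc(C(=O)Nc3ccc(C4CCCCC4)cc3)[nH]c2c1`: 36200 nM

The read-out here is an ADME assay on BJ cells (Homo sapiens) for antiproliferative activity, with a stated time of 72 h; a lower number here means that less compound is needed, a higher number that more compound is needed for the effect. In this assay, among the measured compounds shown here, compound 2 gives 36200 nM, the only true number so far.

Compound 1 gives > 51700 nM, which is a limit of the assay and not a number.

The next compound to be read is compound 3 `COc1cc(OC)c2c(=O)cc(C(=O)Nc3ccc(-n4cccc4)cc3)[nH]c2c1`. It keeps the amide and the shared core of compound 2 and changes one group: 1H-pyrrol-1-yl in place of cyclohexyl on an aromatic carbon. In words, 1H-pyrrol-1-yl stands in place of cyclohexyl on an aromatic carbon, para to a large group.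

For the measured compounds named here, the series holds no measured step between two compounds, so nothing yet sizes this change. The expectation therefore rests on compound 2 at 36200 nM, and no shift beyond the scatter is expected in either direction in this assay. The expected result is a 1.2-fold lower number from compound 2 to compound 3 (0.08 log units; within the scatter), a small step with no firm direction. A report as a limit would also fit this expectation. For compound 3 the estimated value is 30000 nM, with an expected range from 12000 nM to 55000 nM.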

Compound 3, half-maximal effective concentration: > 77000 nM
Compound 3: a limit, no number; the forecaster's own chance of this, stated with the estimate: 40%; at least 2.5-fold (0.40 log units) between middle value and limit.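

In this assay, among the compounds shown here, putting 1H-pyrrol-1-yl in place of cyclohexyl on an aromatic carbon, para to a large group, gives an at least 2.1-fold higher number from compound 2 to compound 3 (0.32 log units; beyond the scatter); this is the first sized change and it lies beyond the scatter. Compound 3 gives > 77000 nM, which is a limit of the assay and not a number, so the step has a lower bound but no upper size: the limit of > 77000 nM in this assay, at which 1 of the 3 values shown sits.

For the compounds shown here, at this position, then, the five-membered aromatic ring does not keep the number that compound 2 shows with the six-membered non-aromatic carbon ring, and compound 2 remains the only compound with a true number.

The pair changes ring size, aromatic character and the nitrogen atom together, so it cannot say which of these goes with the higher number. From the compounds shown here alone, how a phenyl group or a piperidin-1-yl group on this same carbon would read stays open, and either would separate aromatic character from the presence of nitrogen.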